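A few compounds are considered here, and "the series" means these few. Any claim that something is new, unique, unknown or untested is made for them only; others in the source may bear on it.

Compound 1 `Cc1c(C)c2c(c(C)c1OC(=O)CCC(=O)O)CCC(C)(C(=O)NC1CC(C)(C)N([O])C(C)(C)C1)O2`: 165000 nM
Compound 2 `Cc1c(C)c2c(c(C)c1O)CCC(C)(C(=O)NC1CC(C)(C)N([O])C(C)(C)C1)O2`: 55000 nM

In a functional assay on MT4 cells (Homo sapiens) for cytotoxicity, read by MTT assay, with a stated time of 72 h (on this read-out lower numbers stand for stronger inhibition and higher numbers for weaker inhibition), compound 1 has the higher of the two numbers, so it is the weaker inhibitor of the pair. Compound 3 `Cc1c(C)c2c(c(C)c1OC(=O)CCC(=O)O)CCC(C)(C(=O)NCC1CC(C)(C)N([O])C1(C)C)O2` has the same atoms as compound 1, joined differently: a group of 11 heavy atoms (9 carbon, 1 nitrogen, 1 oxygen; one five-membered non-aromatic ring with 1 hetero atom) in place of a group of 11 heavy atoms (9 carbon, 1 nitrogen, 1 oxygen; one six-membered non-aromatic ring with 1 hetero atom), on an amide-type nitrogen. Among the compounds with values here, the only measured step, a 3.0-fold lower number from compound 1 to compound 2 (0.48 log units; beyond the scatter), is modest and concerns a different place, an oxygen on an aromatic ring, so it gives no direct guide to this change. No step beyond the usual scatter is therefore expected. The expected change is a 1.2-fold lower number from compound 1 to compound 3 (0.07 log units; within the scatter). The estimated value for compound 3 is 140000 nM, with an expected range of 60000 nM to 300000 nM.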

Compound 3, half-maximal inhibitory concentration: > 300000 nM
Compound 3 was reported as a limit (the forecaster's own chance of this, stated with the estimate: 15%); middle value at least 2.1-fold (0.33 log units) from the limit.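

In this assay, the five-membered ring group in place of the six-membered one on the amide-type nitrogen, with the same atoms joined differently, gives an at least 1.8-fold higher number from compound 1 to compound 3 (0.25 log units; that floor lies within the scatter) and so shows no lower number for this change. From the compounds shown here alone, the floor of that step lies within the scatter, so how far the number rises stays unknown. Compound 3 gives a limit, not a number: the limit of > 300000 nM in this assay, at which 1 of the 3 values shown sits.

Open, going by these compounds, is how a longer chain or an amine on the amide-type nitrogen would read here. Also open, on these data alone, is whether hydrogen in place of (2-carboxyethyl)carbonyl would lower the number of compound 3 too.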